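Triazole aryl swap on a spirooxindole core: predicting compound 3

The source may report more compounds than this note shows. Statements on the series, on what has been measured and on what is new or still open speak of the compounds shown alone.

Compounds measured so far:
compound 1 `N#CC1=C(N)Oc2c(N)cc3nc4ccccc4nc3c2C12C(=O)N(Cc1cnnn1-c1cccc(Br)c1)c1ccccc12` — > 50000 nM
compound 2 `N#CC1=C(N)Oc2c(N)cc3nc4ccccc4nc3c2C12C(=O)N(Cc1cnnn1-c1ccccc1Br)c1ccccc12` — 38000 nM

Among the measured compounds shown here, in a functional assay on HepG2 cells (Homo sapiens) for antiproliferative activity, read by MTT assay, with a stated time of 48 h (a lower number here means a stronger inhibitor, a higher number a weaker inhibitor), compound 2 gives 38000 nM, the only number recorded in this assay for the shared core. In this assay compound 1 gives > 50000 nM, which is a limit of the assay rather than a number. For the measured compounds named here, the one measured step, an at least 1.3-fold lower number from compound 1 to compound 2 (0.11 log units; that floor lies within the scatter), therefore has a floor that lies within the scatter and does not show a real change.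

Compound 3 `Cc1cc(C)cc(-n2nncc2CN2C(=O)C3(C(C#N)=C(N)Oc4c(N)cc5nc6ccccc6nc5c43)c3ccccc32)c1` differs from compound 2 as follows: 3,5-dimethylphenyl in place of 2-bromophenyl on an aromatic nitrogen The aryl group on the aromatic nitrogen has already been varied once, and that step stayed within the scatter, so no step beyond the scatter is expected from this assay on going from compound 2 to compound 3, with a 1.1-fold higher number from compound 2 to compound 3 (0.02 log units; within the scatter) as the expected shift. Compound 3 is estimated at 40000 nM, between 12000 nM and 130000 nM, with a fair chance that only a limit is reported.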

Compound 3, half-maximal inhibitory concentration: > 50000 nM
Compound 3 gave a limit, no number; the forecaster's own chance of this, stated with the estimate: 40%; at least 1.2-fold (0.09 log units) between middle value and limit.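

In this assay, putting 3,5-dimethylphenyl in place of 2-bromophenyl gives an at least 1.3-fold higher number from compound 2 to compound 3 (0.11 log units; that floor lies within the scatter), so this second change of the aryl group on the aromatic nitrogen also shows no real change. The step from compound 1 to compound 3 cannot be read, as both values are limits. With this result, compound 2 remains the only compound with a number, and the remaining values on the shared core fall at one limit: the limit of > 50000 nM in this assay, at which 2 of the 3 values shown sit.

On these data alone, whether any group on this aromatic nitrogen can bring the number clearly down from that limit remains open. The compounds shown carry only bromophenyl and dimethylphenyl groups there, so they do not tell how a phenyl ring bearing an amine or a carboxylic acid, or a longer chain in place of the aryl group, would behave.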